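A fluoro to bromo swap on compound 2

The compounds below may be only part of what the source reports. "The series", "measured", "known", "first", "only" and "open" are said of these compounds alone.

In a functional assay on HT-29 cells (Homo sapiens) for inhibition, read by sulforhodamine B assay, with a stated time of 48 h (a lower number here means a stronger inhibitor of growth, a higher number a weaker inhibitor of growth), compound 1 `CCOC(=O)c1nn(-c2ccccc2)c(-c2ccc(F)cc2)c1CNC(C)(C)C` gives 65400 nM; 29900 nM (2 entries). For compound 2 `CC(C)(C)NCc1c(C(=O)O)nn(-c2ccccc2)c1-c1ccc(F)cc1` the result in this assay is > 680000 nM, which is a limit of the assay and not a number. Compound 3 `CC(C)(C)NCc1c(C(=O)O)nn(-c2ccccc2)c1-c1ccc(Br)cc1` differs from compound 2 in one place: bromo in place of fluoro on an aromatic carbon. Within the data shown here, no pair of measured compounds shows what this swap does, so no step beyond the scatter is expected in this assay, and no direction can be given. This expectation starts from compound 2 and its limit of > 680000 nM. The expected change is an at least 1.0-fold lower number from compound 2 to compound 3 (0.01 log units; that floor lies within the scatter). For compound 3 the estimated value is 650000 nM, with an expected range from 250000 nM to 1200000 nM.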

Compound 3, concentration for 50% growth inhibition: > 585000 nM
Compound 3: only a limit was reported; the forecaster's own chance of this, stated with the estimate: 65%; the middle value does not contradict the limit.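

In this assay compound 3 gives > 585000 nM, which is a limit of the assay and not a number. Compound 2 gives > 680000 nM, also a limit. No step can be read between compound 2 and compound 3. Still open, from the compounds shown here alone, is what bromo in place of fluoro does to growth inhibition.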